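Swapping Methoxy for Nitro on a Weak Inhibitor

The source may hold more compounds than are shown below. What is called first, only, known or untested is meant among the compounds shown, and "the series" means these compounds.

Three measured compounds share one core and differ only in the aryl group on an aromatic nitrogen. Compound 1 `N#CC1=C(N)Oc2c(N)cc3nc4ccccc4nc3c2C12C(=O)N(Cc1cnnn1-c1ccccc1Br)c1ccccc12` carries a 2-bromophenyl group there, and in a functional assay on A549 cells (Homo sapiens) for antiproliferative activity, read by MTT assay, with a stated time of 48 h (a lower number here means a stronger inhibitor, a higher number a weaker inhibitor), compound 1 gives 27400 nM. Compound 2 `CC(=O)Nc1ccc(-n2nncc2CN2C(=O)C3(C(C#N)=C(N)Oc4c(N)cc5nc6ccccc6nc5c43)c3ccccc32)cc1` carries a 4-acetamidophenyl group. In this assay compound 2 reaches only a limit of the assay, > 50000 nM, which is not a number. Compound 3 `COc1ccc(-n2nncc2CN2C(=O)C3(C(C#N)=C(N)Oc4c(N)cc5nc6ccccc6nc5c43)c3ccccc32)cc1` carries a 4-methoxyphenyl group. In this assay compound 3 likewise reaches only a limit, > 50000 nM. Compound 3 thus stands where two of the three values sit, at the limit (the limit of > 50000 nM in this assay, at which 2 of the 3 values shown sit), and the step of an at least 1.8-fold higher number from compound 1 to compound 3 (0.26 log units; that floor lies within the scatter) shows how little can be read from that position.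

Compound 4 `N#CC1=C(N)Oc2c(N)cc3nc4ccccc4nc3c2C12C(=O)N(Cc1cnnn1-c1ccc([N+](=O)[O-])cc1)c1ccccc12` differs from compound 3 by nitro in place of methoxy on an aromatic carbon. Among the measured compounds shown here, two measured steps bear on this exchange: the step of an at least 1.8-fold higher number from compound 1 to compound 3 (0.26 log units; that floor lies within the scatter) and the step that the two limits leave unreadable from compound 2 to compound 3. Neither gives a readable size, so no step beyond the scatter can be expected, and compound 4 is estimated to sit at a number no higher from compound 3 to compound 4 (the limit leaves the size open). Compound 4 is therefore expected to give 50000 nM, with a range from 20000 nM to 120000 nM.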

Compound 4, half-maximal inhibitory concentration: > 50000 nM
Compound 4 ended at the assay's limit (the forecaster's own chance of this, stated with the estimate: 65%); the middle value sits exactly at the limit.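

In this assay compound 4 gives > 50000 nM, which is a limit of the assay and not a number. Replacing methoxy with nitro therefore brings no measurable activity to this aryl group, and the limit now holds most of the set: the limit of > 50000 nM in this assay, at which 3 of the 4 values shown sit. The steps among compound 2, compound 3 and compound 4 cannot be read, so these three groups cannot be put in any order, and the only step with a floor is an at least 1.8-fold higher number from compound 1 to compound 4 (0.26 log units; that floor lies within the scatter), which means that even the 2-bromophenyl group is not shown to differ from the 4-nitrophenyl group beyond the usual scatter.

The compounds shown leave open how far beyond the limit compound 2, compound 3 and compound 4 lie, and whether the position can give a clearly stronger inhibitor at all. An amine, a carboxylic acid or a bromine in place of the methoxy, on the same aromatic carbon, would show whether any value falls below the limit and whether the bromine of compound 1 counts for anything there.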